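Swapping the Heteroaromatic Ring of a Chemokine Receptor Antagonist

The compounds below may be only part of what the source reports. "The series", "measured", "known", "first", "only" and "open" are said of these compounds alone.

Compound 1 `CC(C)(C)c1ccc(S(=O)(=O)Nc2ccc(Cl)cc2-c2ncccc2N)cc1`: 95 nM
Compound 2 `CC(C)(C)c1ccc(S(=O)(=O)Nc2ccc(Cl)cc2-c2nc(N)ncc2O)cc1`: 4 nM

In a functional assay on isolated protein for antagonist activity at C-C chemokine receptor type 9 (Homo sapiens), read by calcium flux, with a stated time of 10 min (on this read-out lower numbers stand for stronger inhibition and higher numbers for weaker inhibition), compound 1 gives 95 nM, and compound 2 gives 4 nM. Compound 2 stands lowest of the two numbers; the step of a 24-fold lower number from compound 1 to compound 2 (1.38 log units; beyond the scatter) is large. Compound 3 `CNc1nccnc1-c1cc(Cl)ccc1NS(=O)(=O)c1ccc(C(C)(C)C)cc1` differs from compound 2 in one place: a group of 8 heavy atoms (5 carbon, 3 nitrogen; one six-membered aromatic ring with 2 hetero atoms) in place of a group of 8 heavy atoms (4 carbon, 3 nitrogen, 1 oxygen; one six-membered aromatic ring with 2 hetero atoms), on an aromatic carbon. Within the data shown here, the one measured step that bears on this exchange is the ring swap from compound 1 to compound 2, which brought in an oxygen-containing ring and cut the number sharply. Compound 3 gives that oxygen up again and carries a methylamino group instead, so it looks closer to compound 1, which gives 95 nM, than to compound 2. A higher number than compound 2 is therefore expected for compound 3, a moderate step of about a 7.5-fold higher number from compound 2 to compound 3 (0.88 log units; beyond the scatter), with wide uncertainty. Compound 3 is estimated at 30 nM, within 8 nM to 120 nM.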

Compound 3, half-maximal inhibitory concentration: 25 nM
Beside the measured number, compound 3's estimate is 1.2-fold (0.08 log units) above it; low and high end bracket the measured number.
By their numbers in this assay, from the lowest: compound 2; then compound 3; then compound 1.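

In this assay, the ring on this aromatic carbon can lose its oxygen and still keep part of the gain: a 3.8-fold lower number from compound 1 to compound 3 (0.58 log units; beyond the scatter) shows that 3-(methylamino)pyrazin-2-yl gives a lower number than 3-aminopyridin-2-yl. Among these compounds, the oxygen-bearing ring of compound 2 still reads better, with a 6.3-fold higher number from compound 2 to compound 3 (0.80 log units; beyond the scatter), so a lower number than that of compound 1 does not depend on having that ring, but the lowest number so far comes with it. Nothing measured here accounts for either difference.

Going by these compounds, each exchange alters the ring and its substituents at once, so the share of each change in these steps stays unknown. On these data alone, it also remains open how a plain amine or a longer ethylamino chain in place of the methylamino group would read.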